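The source may hold more compounds than are shown below. What is called first, only, known or untested is meant among the compounds shown, and "the series" means these compounds.

Measured so far in a functional assay on OVCAR-3 cells (Homo sapiens) for antiproliferative activity, read by spectrophotometry, with a stated time of 2 days; on this read-out higher numbers stand for weaker inhibition of growth and lower numbers for stronger inhibition of growth:
compound 1, `CN(c1cccc2c1CN(c1nc(Nc3ccc(C(F)(F)F)cc3)ncc1C(F)(F)F)C2)S(C)(=O)=O` — compound 1 gives > 30000 nM, which is a limit of the assay.
compound 2, `CN(c1cccc2c1CN(c1nc(Nc3ccc(Cl)c(C(F)(F)F)c3)ncc1C(F)(F)F)C2)S(C)(=O)=O` — compound 2 gives > 50000 nM, also a limit.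
compound 3, `COc1cc(Nc2ncc(C(F)(F)F)c(N3Cc4cccc(N(C)S(C)(=O)=O)c4C3)n2)cc(OC)c1` — compound 3 gives 630 nM.

Compound 1 thus stands only at a limit (the limit of > 30000 nM in this assay, at which 1 of the 3 values shown sits), and compound 2 at a second one (the limit of > 50000 nM in this assay, at which 1 of the 3 values shown sits), so the step between them is unreadable a step that the two limits leave unreadable from compound 1 to compound 2. Compound 4, `Cc1cc(C)cc(Nc2ncc(C(F)(F)F)c(N3Cc4cccc(N(C)S(C)(=O)=O)c4C3)n2)c1`, differs from compound 1 by 3,5-dimethylphenyl in place of 4-(trifluoromethyl)phenyl on a nitrogen on an aromatic ring. Among the measured compounds shown here, the one step that bears on it is an at least 47-fold lower number from compound 1 to compound 3 (1.67 log units; beyond the scatter), and an at least 79-fold lower number from compound 2 to compound 3 (1.89 log units; beyond the scatter) runs the same way. A large downward step is therefore expected, an at least 15-fold lower number from compound 1 to compound 4 (1.17 log units; beyond the scatter). Compound 4 is estimated at 2000 nM, within a range of 300 nM to 15000 nM.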

Compound 4, concentration for 50% growth inhibition: > 30000 nM
Compound 4 ended at the assay's limit (the forecaster's own chance of this, stated with the estimate: 25%); middle value at least 15-fold (1.17 log units) from the limit.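

Compound 4 stands at a limit of the assay: the limit of > 30000 nM in this assay, at which 2 of the 4 values shown sit. In this assay, exchanging 3,5-dimethoxyphenyl for 3,5-dimethylphenyl on this nitrogen gives an at least 47-fold higher number from compound 3 to compound 4 (1.67 log units; beyond the scatter), so the same substitution pattern with methyl groups does not retain the growth inhibition seen with methoxy groups. The steps from compound 1 and from compound 2 to compound 4 cannot be read, since both ends are limits.

Open, going by these compounds, is whether one methoxy group is enough, as in 3-methoxyphenyl. Also open, on these data alone, is how longer ethoxy groups or a morpholine on the phenyl ring would read out.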